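This account rests on a few compounds, and the source may have more. Where it says the series, first, only, none or still open, it means among the compounds named here.

Working notes on the series.

The shared core carries an aromatic amine bearing a phenyl substituent and, on the neighbouring nitrogen, a benzyl group whose aryl part varies. Compound 1 `CCOC(=O)[C@H](CCC(=O)O)NC(=O)c1ccc(CNc2nc3cc(N)cc(N)c3nc2-c2ccccc2)cc1` carries an amide-linked glutamate ester on that aryl part; in a functional assay on SK-MEL-2 cells (Homo sapiens) for inhibition, read by sulforhodamine B assay, with a stated time of 48 h (a higher number here means a weaker inhibitor of growth, a lower number a stronger inhibitor of growth), compound 1 gives 27500 nM. Compound 2 `Nc1cc(N)c2nc(-c3ccccc3)c(NCc3ccc(Cl)c(Cl)c3)nc2c1` carries a 3,4-dichlorophenyl instead; in this assay compound 2 gives 1910 nM. Going by the values given here, compound 2 thus stands at the lowest of the two numbers so far, with compound 1 the nearest and well beyond the scatter of it.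

Compound 3 `COc1ccc(CNc2nc3cc(N)cc(N)c3nc2-c2ccccc2)cc1OC` is the next point. It differs from compound 2 in one place: 3,4-dimethoxyphenyl in place of 3,4-dichlorophenyl on a saturated chain carbon bound to a nitrogen on an aromatic ring. Among the compounds with values here, no measured pair in the set isolates this change, so the size of the step cannot be read from the data. Within the data shown here, both halogen and methoxy variants of the aryl part sit on the same saturated chain carbon, and the only measured comparison spans a far larger structural change. A modest weakening is expected, with the step from compound 2 to compound 3 estimated at a 2.4-fold higher number from compound 2 to compound 3 (0.37 log units; beyond the scatter). In this assay compound 3 is therefore estimated at 4500 nM, with an expected range from 1200 nM to 18000 nM.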

Compound 3, concentration for 50% growth inhibition: 8710 nM
For compound 3 the middle estimate is 1.9-fold (0.29 log units) below the measured one; the measured number falls inside the stated range.
By their numbers in this assay, from the lowest: compound 2; then compound 3; then compound 1.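

Going by these compounds alone, this is the first step that isolates one change on the aryl part: in this assay, 3,4-dimethoxyphenyl in place of 3,4-dichlorophenyl on a saturated chain carbon bound to a nitrogen on an aromatic ring gives a 4.6-fold higher number from compound 2 to compound 3 (0.66 log units; beyond the scatter) and so separates the two compounds beyond the usual scatter. The position therefore responds to this exchange, and the 3,4-dichlorophenyl group holds the lower number of the pair, even though the 3,4-dimethoxyphenyl group has more heavy atoms and brings hydrogen-bond acceptors that the 3,4-dichlorophenyl group lacks. No measurement of any property of these two groups is at hand to account for the step.

Both substituents change together in this pair, so the compounds shown leave open whether the chlorines, the methoxy groups or both set the size of the step. Also open, as far as these compounds go, is where an unsubstituted phenyl, or a phenyl carrying a single chlorine, a single methoxy group or a nitrile, would stand in this assay relative to compound 2 and compound 3.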